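The source may report more compounds than this note shows. Statements on the series, on what has been measured and on what is new or still open speak of the compounds shown alone.

Measured so far in a functional assay on SK-MEL-28 cells (Homo sapiens) for inhibition, read by sulforhodamine B assay, with a stated time of 48 h, tested at 10 uM; on this read-out higher numbers stand for a weaker effect at the one concentration tested and lower numbers for a stronger effect:
- compound 1, `COc1cc(Cl)cc(-c2nn(-c3cccc(NC(=O)Nc4cccc(C(F)(F)F)c4)c3)cc2-c2ccncc2)c1` — 14.1%
- compound 2, `COc1cc(Cl)cc(-c2nn(-c3cccc(NC(=O)Nc4ccc(Cl)c(C(F)(F)F)c4)c3)cc2-c2ccncc2)c1` — 23.6%

Compound 2 holds the higher of the two numbers, its nearest neighbour being compound 1; the step of a number 9.5 percentage points higher from compound 1 to compound 2 (within the scatter) lies within the scatter. Compound 3, `COc1cc(Cl)cc(-c2nn(-c3cccc(NC(=O)c4ccc(Cl)c(Cl)c4)c3)cc2-c2ccncc2)c1`, is not yet measured. It differs from compound 2 by 3,4-dichlorophenyl in place of (4-chloro-3-(trifluoromethyl)phenyl)amino on a carbonyl carbon. Going by the values given here, no measured step touches a change of this kind, and the single step on record is itself within the scatter, so no step beyond the scatter is expected in this assay; the estimate for compound 3 is 25% with a range of 5% to 55%. The expected step is a number 1.4 percentage points higher from compound 2 to compound 3 (within the scatter).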

Compound 3, a percentage reported as activity, at one concentration (the size of the read-out at that concentration, not a potency): 87.8%
Estimate against measurement, compound 3: 62.8 percentage points below; the whole stated range lies below it.
By their numbers in this assay, from the lowest: compounds 1 and 2 (each within the scatter of the next); then compound 3.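

In this assay, the group on the carbonyl carbon turns out to matter far more than the chloro change did: 3,4-dichlorophenyl in place of (4-chloro-3-(trifluoromethyl)phenyl)amino gives a number 64.2 percentage points higher from compound 2 to compound 3 (beyond the scatter) and so a much weaker effect at the one concentration tested. The same kind of change from (3-(trifluoromethyl)phenyl)amino gives a number 73.7 percentage points higher from compound 1 to compound 3 (beyond the scatter) and thus the same loss from either amino group. No measurement on hand explains this loss.

The change removes the amino nitrogen and alters the ring substituents together, so the compounds shown do not separate the two. A (3,4-dichlorophenyl)amino group on the same carbonyl carbon would do so.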